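Swapping 4-methoxybenzyl for 2,3-dichlorobenzyl on a shared core

The source may hold more compounds than are shown below. What is called first, only, known or untested is meant among the compounds shown, and "the series" means these compounds.

Compound 1 `O=C(NCc1cccc(Cl)c1Cl)c1c([N+](=O)[O-])noc1-c1ccc([N+](=O)[O-])cc1`: "not determined" (no result reported)
Compound 2 `O=C(NCc1ccccc1)c1c([N+](=O)[O-])noc1-c1ccc(Cl)cc1Cl`: "not determined" (no result reported)
Compound 3 `COc1ccc(CNC(=O)c2c([N+](=O)[O-])noc2-c2ccc(Cl)cc2Cl)cc1`: 80500 nM

For the measured compounds named here, in an ADME assay on J774.A1 cells (Mus musculus) for cytotoxicity, read by MTT assay, with a stated time of 48 h (a higher number here means that more compound is tolerated, a lower number that less compound is tolerated), compound 3 gives 80500 nM, and this is the only number available. Compound 1 and compound 2 have no reported result, so compound 3 cannot be ranked against either of them.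

The next compound to be measured is compound 4 `O=C(NCc1cccc(Cl)c1Cl)c1c([N+](=O)[O-])noc1-c1ccc(Cl)cc1Cl`. It keeps the shared core of compound 3 and carries 2,3-dichlorophenyl in place of 4-methoxyphenyl on a saturated chain carbon bound to an amide-type nitrogen. The same difference can be read as 4-methoxybenzyl to 2,3-dichlorobenzyl.

Going by the values given here, no pair of measured compounds shows what a single change does in this assay, so the expectation has little to stand on. Among the compounds with values here, its only anchor is compound 3 at 80500 nM. A modest shift towards less compound being tolerated is expected, though it may not clear the usual scatter by much. The estimated size of this shift is a 1.6-fold lower number from compound 3 to compound 4 (0.21 log units; within the scatter). Compound 4 is expected at 50000 nM, within an estimated range from 20000 nM to 120000 nM.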

Compound 4, half-maximal cytotoxic concentration: 81800 nM
Estimate against measurement, compound 4: 1.6-fold (0.21 log units) below; measured number inside the range.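

In this assay, the exchange of 4-methoxybenzyl for 2,3-dichlorobenzyl on the shared core gives a 1.0-fold higher number from compound 3 to compound 4 (0.01 log units; within the scatter), so the two compounds cannot be told apart in this read-out. For the compounds shown here, until now there was a single number and no pair, whereas this step gives a first reading at this position, on a saturated chain carbon bound to an amide-type nitrogen: the 4-methoxyphenyl that leaves carries a hydrogen-bond acceptor, the 2,3-dichlorophenyl that enters carries none, and no separable difference in tolerated concentration goes with the exchange. Nothing measured here bears on why the two compounds read alike.

From the compounds shown here alone, this is one pair on one core, and with no number for compound 1 or compound 2, it remains open whether the same exchange would read alike with the 4-nitrophenyl of compound 1 on the core, or how the plain benzyl of compound 2 would compare. Going by these compounds, it also remains open whether a group of a different kind in place of 2,3-dichlorophenyl, such as an amine or a carboxylic acid, would separate from these two values.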